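Naphthalen-2-yl to cyclohexyl on a sulfur

The source may report more compounds than this note shows. Statements on the series, on what has been measured and on what is new or still open speak of the compounds shown alone.

Within the data shown here, in a functional assay on U2OS cells (Homo sapiens) for antiproliferative activity, read by MTT assay, with a stated time of 72 h (on this read-out higher numbers stand for weaker inhibition and lower numbers for stronger inhibition), compound 2 (`O=C(CSc1ccc2ccccc2c1)Nc1ccc2nc(NC(=O)c3ccc(C(F)(F)F)cc3)sc2c1`) gives 3940 nM, the lower of the two numbers so far, while compound 1 (`O=C(CSc1ncc[nH]1)Nc1ccc2nc(NC(=O)c3ccc(C(F)(F)F)cc3)sc2c1`) gives 18800 nM. Compound 3 (`O=C(CSC1CCCCC1)Nc1ccc2nc(NC(=O)c3ccc(C(F)(F)F)cc3)sc2c1`) carries cyclohexyl in place of naphthalen-2-yl on a sulfur. Among the measured compounds shown here, the only measured step at this sulfur is a 4.8-fold lower number from compound 1 to compound 2 (0.68 log units; beyond the scatter), which is modest and replaces 1H-imidazol-2-yl with naphthalen-2-yl. Cyclohexyl is, like naphthalen-2-yl, of carbon only, so a move of smaller or similar size towards a higher number is expected, estimated as a 2.0-fold higher number from compound 2 to compound 3 (0.31 log units; beyond the scatter). The estimate for compound 3 is 8000 nM, with an expected range of 3000 nM to 20000 nM.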

Compound 3, half-maximal inhibitory concentration: 12300 nM
For compound 3 the middle estimate is 1.5-fold (0.19 log units) below the measured one; the range from low to high includes it.
By their numbers in this assay, from the lowest: compound 2; then compounds 3 and 1 (each within the scatter of the next).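

Replacing naphthalen-2-yl with cyclohexyl gives a 3.1-fold higher number from compound 2 to compound 3 (0.49 log units; beyond the scatter) in this assay, so a group of carbon only on this sulfur is not enough to keep the lower number of compound 2. The step of a 1.5-fold lower number from compound 1 to compound 3 (0.18 log units; within the scatter) does not separate cyclohexyl from 1H-imidazol-2-yl, which leaves naphthalen-2-yl alone among these three groups. No measurement available here accounts for this difference.

From the compounds shown here alone, it remains open whether a phenyl ring, a benzyl group or a straight butyl chain on this sulfur would track with naphthalen-2-yl or with cyclohexyl.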